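From 3-Chlorophenyl to 4-Bromophenyl on a Shared Core

The source may report more compounds than this note shows. Statements on the series, on what has been measured and on what is new or still open speak of the compounds shown alone.

Three compounds with a shared core and different aryl groups on an aromatic nitrogen have been tested in a functional assay on SGC-7901 cells (Homo sapiens) for inhibition, read by MTT assay, with a stated time of 24 h; a lower number here means a stronger inhibitor, a higher number a weaker inhibitor: compound 1 `CC1(C)[C@H]2CC[C@]1(C)N(Cc1cn(-c3ccc(F)cc3)nn1)C(=O)C2`, compound 2 `CC1(C)[C@H]2CC[C@]1(C)N(Cc1cn(-c3ccccc3Cl)nn1)C(=O)C2` and compound 3 `CC1(C)[C@H]2CC[C@]1(C)N(Cc1cn(-c3cccc(Cl)c3)nn1)C(=O)C2`. Compound 3 gives 510 nM and sits level with compound 1, which gives 500 nM; the data show a 1.0-fold higher number from compound 1 to compound 3 (0.01 log units; within the scatter). Compound 2 gives 220 nM, so the two others are the weaker inhibitors, with a 2.3-fold higher number from compound 2 to compound 3 (0.37 log units; beyond the scatter).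

Compound 4 `CC1(C)[C@H]2CC[C@]1(C)N(Cc1cn(-c3ccc(Br)cc3)nn1)C(=O)C2` has 4-bromophenyl in place of 3-chlorophenyl on an aromatic nitrogen. Among the measured compounds shown here, no compound with bromine has been measured, so this rests on indirect evidence. Swapping 4-fluorophenyl for 3-chlorophenyl changed nothing measurable, as a 1.0-fold higher number from compound 1 to compound 3 (0.01 log units; within the scatter) shows. Only the 2-chlorophenyl group of compound 2 stood apart, with a 2.3-fold lower number from compound 1 to compound 2 (0.36 log units; beyond the scatter), and compound 4 does not carry that group. Three compounds make a thin basis, so the range must stay wide.

No change beyond the scatter is therefore expected in this assay, and the estimate is a 1.1-fold lower number from compound 3 to compound 4 (0.03 log units; within the scatter). Compound 4 is expected at 480 nM, with an estimated range of 240 nM to 950 nM.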

Compound 4, half-maximal inhibitory concentration: 450 nM
The estimate for compound 4 lay 1.1-fold (0.03 log units) above the measured number; the range from low to high includes it.
By their numbers in this assay, from the lowest: compound 2; then compounds 4, 1 and 3 (each within the scatter of the next).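

At this position, the data in this assay now show that a bromo group can take the place of the fluoro group on the phenyl ring without a change beyond the scatter (a 1.1-fold lower number from compound 1 to compound 4 (0.05 log units; within the scatter)), and the same holds when 4-bromophenyl replaces 3-chlorophenyl (a 1.1-fold lower number from compound 3 to compound 4 (0.05 log units; within the scatter)). Compounds 1, 3 and 4 therefore read as one level across three different halogen-bearing phenyl groups, and compound 2 is the one that goes against this, since its 2-chlorophenyl group stays apart from the new 4-bromophenyl compound by a step beyond the scatter (a 2.0-fold higher number from compound 2 to compound 4 (0.31 log units; beyond the scatter)). Nothing measured here explains why these three compounds sit level or why compound 2 stands apart.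

Going by these compounds, a plain phenyl group, or a phenyl ring carrying an amine or a carboxylic acid, would show whether a halogen matters at all on this aryl group, and that remains open. It also remains open whether the result of compound 2 is tied to chlorine itself, as the 2-chlorophenyl group is the only one of its kind among the compounds shown.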